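The source may report more compounds than this note shows. Statements on the series, on what has been measured and on what is new or still open speak of the compounds shown alone.

Two compounds of the series carry a number in an assay on Sf9 cells for inhibition of mitogen-activated protein kinase kinase kinase 14 variant S549D (Homo sapiens), with a stated time of 30 min, in the presence of a further agent that is not named here; a higher number here means a weaker inhibitor, a lower number a stronger inhibitor. Compound 1 `C=Cc1ccnc(C#Cc2ccc3ncn(-c4ccnc(N)n4)c3c2)c1` gives 1580 nM; compound 2 `C#Cc1cnc(C#Cc2ccc3ncn(-c4ccnc(N)n4)c3c2)nc1` gives 25100 nM, the higher of the two numbers, reached by a 16-fold higher number from compound 1 to compound 2 (1.20 log units; beyond the scatter). Compound 3 `Cc1ccnc(C#Cc2ccc3ncn(-c4ccnc(N)n4)c3c2)n1` differs from compound 2 by a group of 7 heavy atoms (5 carbon, 2 nitrogen; one six-membered aromatic ring with 2 hetero atoms) in place of a group of 8 heavy atoms (6 carbon, 2 nitrogen; one six-membered aromatic ring with 2 hetero atoms), on a triple-bonded carbon. For the measured compounds named here, only the step from compound 1 to compound 2 bears on this change, and it altered ring and pendant group together, so its size cannot be assigned to either part alone. Retaining the ring of compound 2 and exchanging only the pendant group is expected to give a moderate lowering, a 2.5-fold lower number from compound 2 to compound 3 (0.40 log units; beyond the scatter). For compound 3 the estimate in this assay is 10000 nM, with a range from 3000 nM to 35000 nM.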

Compound 3, half-maximal inhibitory concentration: 1580 nM
Estimate against measurement, compound 3: 6.3-fold (0.80 log units) above, outside the stated range (below it).
By their numbers in this assay, from the lowest: compounds 1 and 3 (each within the scatter of the next); then compound 2.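

In this assay, the 4-methylpyrimidin-2-yl group on the triple-bonded carbon gives a 16-fold lower number from compound 2 to compound 3 (1.20 log units; beyond the scatter), although both groups carry one six-membered aromatic ring with 2 hetero atoms. The high number of compound 2 therefore does not follow from the hetero atom count of the ring alone. The hetero atom count also does not separate the other pair, with no change at the digits printed from compound 1 to compound 3 (within the scatter).

On these data alone, whether an amine or a longer chain in place of the methyl of compound 3 would hold this number remains open. Nothing available here accounts for the size of either step.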